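The source may hold more compounds than are shown below. What is called first, only, known or untested is meant among the compounds shown, and "the series" means these compounds.

Compound 1 `CC1=C([Se]CC(OC(=O)CC[Se]c2ccccc2)C(=O)NCCCCCC(=O)OCc2ccccc2)C(=O)c2ccccc2C1=O`: 4000 nM
Compound 2 `CC1=C([Se]CC(OC(=O)[C@@H](CSSC(C)(C)C)NC(=O)OC(C)(C)C)C(=O)NC(C)(C)C)C(=O)c2ccccc2C1=O`: 2000 nM

In a functional assay on A-431 cells (Homo sapiens) for cytotoxicity, read by MTT assay, with a stated time of 24 h (a lower number here means a stronger inhibitor, a higher number a weaker inhibitor), compound 1 gives 4000 nM, the higher of the two numbers, while compound 2 gives 2000 nM; the gap between them lies within the scatter, so neither can be called stronger. Compound 3 `CC1=C([Se]CC(OC(=O)CNC(=O)OC(C)(C)C)C(=O)NCCCCCC(=O)OCc2ccccc2)C(=O)c2ccccc2C1=O` differs from compound 1 in one place: a group of 8 heavy atoms (5 carbon, 1 nitrogen, 2 oxygen; no ring) in place of a group of 8 heavy atoms (7 carbon, 1 selenium; one six-membered aromatic ring of carbon only), on a saturated chain carbon bound to a carbonyl carbon. For the measured compounds named here, with only two measured compounds and no step between them, the expected change for this assay is none beyond the scatter, so compound 3 is estimated at 4000 nM, ranging from 1500 nM to 11000 nM, which means an expected step of no change at the digits printed from compound 1 to compound 3 (within the scatter).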

Compound 3, half-maximal inhibitory concentration: 5000 nM
Estimate against measurement, compound 3: 1.3-fold (0.10 log units) below; low and high end bracket the measured number.
By their numbers in this assay, from the lowest: compounds 2, 1 and 3 (each within the scatter of the next, the first and the last beyond it).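

At the saturated chain carbon bound to a carbonyl carbon, replacing the group with selenium and an aromatic ring by (tert-butoxycarbonyl)amino gives a 1.3-fold higher number from compound 1 to compound 3 (0.10 log units; within the scatter) in this assay. This position can therefore lose that ring and that selenium, and gain a hydrogen-bond donor, with no change that can be told from the scatter. No measurement shown explains this result.

From the compounds shown here alone, whether a free amine, a carboxylic acid or a longer chain at this position would also stay within the scatter remains open. A single step also cannot show whether the same holds on other parts of the molecule.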